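Polyazamacrocycle triacetic acids: aminophenyl against nitrophenyl

This account rests on a few compounds, and the source may have more. Where it says the series, first, only, none or still open, it means among the compounds named here.

Measured so far:
compound 1, `O=C(O)CN1CCN(CCCn2cccc(O)c2=O)CCN(CC(=O)O)CC1`: 4500 nM
compound 2, `Nc1ccc(CCCN(CCN2CCN(CC(=O)O)CCN(CC(=O)O)CC2)CC(=O)O)cc1`: 1500 nM

In a functional assay on HepG2 cells (Homo sapiens) for antiproliferative activity, read by MTT assay, with a stated time of 72 h (on this read-out lower numbers stand for stronger inhibition and higher numbers for weaker inhibition), compound 2 gives 1500 nM. In the same assay compound 1 gives 4500 nM. Compound 2 therefore stands at the lower of the two numbers, and its gap to compound 1 lies beyond the usual scatter. The two compounds differ in more than one place, so that gap cannot be tied to any single change.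

Compound 3 `O=C(O)CN(CCCc1ccc([N+](=O)[O-])cc1)CCN1CCN(CC(=O)O)CCN(CC(=O)O)CC1` has not been measured. It differs from compound 2 by nitro in place of amino on an aromatic carbon. Among the compounds with values here, no measured pair in this set carries the same change, so there is no step to lean on; what is known is only that the rest of the molecule is kept. On that basis the step from compound 2 to compound 3 is expected to be small, a 1.5-fold higher number from compound 2 to compound 3 (0.17 log units; within the scatter), with a slight lean toward a higher number and no confident claim of a shift beyond the scatter. Compound 3 is accordingly estimated at 2200 nM in this assay, with a range from 700 nM to 7000 nM.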

Compound 3, half-maximal inhibitory concentration: 1400 nM
The estimate for compound 3 lay 1.6-fold (0.20 log units) above the measured number, and the stated range covers the measured number.
By their numbers in this assay, from the lowest: compounds 3 and 2 (each within the scatter of the next); then compound 1.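

In this assay, nitro in place of amino on an aromatic carbon, para to a large group, gives a 1.1-fold lower number from compound 2 to compound 3 (0.03 log units; within the scatter). Within the data shown here, this is the first comparison that isolates one place, as compound 1 and compound 2 differ in more than one. At this position, the change from the 4-aminophenyl to the 4-nitrophenyl group removes the hydrogen-bond donor counted for amino and adds heavy atoms with no shift beyond the scatter, and nothing available bears on why the two compounds read alike.

One pair at one position does not show how far this tolerance extends: an acetamide, a carboxylic acid or a chlorine on the same aromatic carbon could still read differently, as could a shorter or longer chain carrying the aromatic ring. Going by these compounds, the gap between compound 1 at 4500 nM and compound 2 at 1500 nM also remains tied to no single change, so the part played by the aminophenyl-bearing side chain against the group in compound 1 stays open.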